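A few compounds are considered here, and "the series" means these few. Any claim that something is new, unique, unknown or untested is made for them only; others in the source may bear on it.

Measured in a functional assay on the whole organism for agonist activity, with Mus musculus as the target; a higher number here means that more compound is needed for the effect, a lower number that less compound is needed:
- Compound 1 `COC(=O)NCC#CCn1cncc1C`: > 100 mg/kg
- Compound 2 `COC(=O)N(C)CC#CCN1CCCC1`: 5.5 mg/kg
- Compound 3 `O=C1OCCN1CC#CCn1ccnc1`: 2 mg/kg

Compound 1 reads > 100 mg/kg, and this is a limit of the assay and not a number. That leaves two true numbers in this assay. Compound 3, at 2 mg/kg, has the lowest of them, and compound 2 stands at 5.5 mg/kg, a gap that lies beyond the usual scatter.

Compound 4 `Cc1cncn1CC#CCN1CCOC1=O` differs from compound 3 in one place: methyl in place of hydrogen on an aromatic carbon. It carries methyl in place of hydrogen on an aromatic carbon, next to the ring atom that bears a large group.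

Among the compounds with values here, no measured pair isolates this change, so its size cannot be read directly. Within the data shown here, the only hint is compound 1, which also bears a methyl on its five-membered aromatic ring and shows the limit > 100 mg/kg. One compound makes a weak guide, so the expectation stays broad. The step expected is a 7.5-fold higher number from compound 3 to compound 4 (0.88 log units; beyond the scatter), upward and beyond the scatter, meaning that more compound would be needed. For compound 4, the estimated value is 15 mg/kg, with an expected range from 4 mg/kg to 80 mg/kg.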

Compound 4, dose for half-maximal effect: > 100 mg/kg
Compound 4 was reported as a limit (the forecaster's own chance of this, stated with the estimate: 25%); middle value at least 6.6-fold (0.82 log units) away from the limit.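

In this assay, within the data shown here, the single change of methyl in place of hydrogen on an aromatic carbon, next to the ring atom that bears a large group, gives an at least 50-fold higher number from compound 3 to compound 4 (1.69 log units; beyond the scatter). Among these compounds, until now no pair of compounds isolated this change, and this pair shows that one added carbon at this place is enough to move the dose needed from the lowest true number in the set to beyond what can be read. Its full size stays unknown, and the step can be stated only as a lower bound because the value of compound 4 sits at a limit of the assay, not at a true number: the limit of > 100 mg/kg in this assay, at which 2 of the 4 values shown sit.

As far as these compounds go, whether a chlorine atom, an ethyl group or a hydroxymethyl group at this same place would raise the dose as strongly remains open, and so does the question of whether it is this place in particular that matters. A methyl on one of the other aromatic carbons of the ring would be needed to answer that second question.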